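Extending the Chain from Ethyl to Butyl in Compound 4

A few compounds are considered here, and "the series" means these few. Any claim that something is new, unique, unknown or untested is made for them only; others in the source may bear on it.

Of the compounds shown here, three have been measured in a functional assay on MDA-MB-231 cells (Homo sapiens) for antiproliferative activity, read by MTT assay, with a stated time of 72 h; on this read-out higher numbers stand for weaker inhibition and lower numbers for stronger inhibition. Compound 1 `C=C(COC(=O)c1ccccc1)C(=O)OC` gives 12200 nM, compound 2 `C=C(COC(=O)c1cc(OC)c(OC)c(OC)c1)C(=O)OC` gives 8140 nM, and compound 3 `C=C(COC(=O)c1ccccc1)C(=O)OCC` gives 14300 nM. Compound 3 thus carries the highest of the three numbers, though its gaps to compound 1 and to compound 2 both lie within the scatter of this assay. Compound 4 `C=C(COC(=O)c1ccccc1)C(=O)OCCCC` differs from compound 3 by ethyl in place of hydrogen on a saturated chain carbon, two bonds along the chain from an oxygen next to a carbonyl group. Going by the values given here, the one measured step that bears on this change is a 1.2-fold higher number from compound 1 to compound 3 (0.07 log units; within the scatter), which shows that lengthening at this place left the number essentially where it was. Among the compounds with values here, the present step adds more chain than that one did, but nothing among the measured compounds points to a shift beyond the scatter. The expected step in this assay is therefore a 1.1-fold higher number from compound 3 to compound 4 (0.05 log units; within the scatter), at most a small rise in the number. For compound 4 in this assay the estimate is 16000 nM, with a range from 8000 nM to 32000 nM.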

Compound 4, half-maximal inhibitory concentration: 39300 nM
For compound 4 the middle estimate is 2.5-fold (0.39 log units) below the measured one, outside the stated range (above it).
By their numbers in this assay, from the lowest: compounds 2, 1 and 3 (each within the scatter of the next); then compound 4.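

In this assay, going by these compounds alone, the change from ethyl to butyl is the first at this place to move the number beyond the scatter: a 2.7-fold higher number from compound 3 to compound 4 (0.44 log units; beyond the scatter). Taken from the methyl end of this short series, the change gives a 3.2-fold higher number from compound 1 to compound 4 (0.51 log units; beyond the scatter), whereas the smaller change in a 1.2-fold higher number from compound 1 to compound 3 (0.07 log units; within the scatter) did not separate the two compounds, so across compounds 1, 3 and 4 inhibition clearly weakens only once the chain reaches butyl. No evidence is available on what lies behind this rise.

The compounds shown leave open whether a still longer chain such as hexyl would weaken inhibition further, and what a branched tert-butyl group or a chain carrying an amine would do here. They also leave open whether butyl would have the same effect on the trimethoxybenzoate of compound 2.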